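Two naphthalene isomers on a shared sulfonyl sulfur

The source may report more compounds than this note shows. Statements on the series, on what has been measured and on what is new or still open speak of the compounds shown alone.

Compound 1 `O=S(=O)(NC1=NCCN1C(=S)SN1CCn2c1nsc2=S)c1ccc(Br)cc1` and compound 2 `O=S(=O)(NC1=NCCN1C(=S)SN1CCn2c1nsc2=S)c1ccc2ccccc2c1` share the same core and differ only in the group on the sulfonyl sulfur. In a functional assay on KYSE-510 cells (Homo sapiens) for antiproliferative activity, read by crystal violet staining, with a stated time of 96 h (on this read-out higher numbers stand for weaker inhibition of growth and lower numbers for stronger inhibition of growth), compound 1 gives a limit, >= 20000 nM. In this assay compound 2 likewise gives a limit, >= 20000 nM. The step that the two limits leave unreadable from compound 1 to compound 2 therefore cannot be read, since both values sit at the limit of >= 20000 nM in this assay, at which 2 of the 2 values shown sit. Compound 2 thus stands at the limit of this assay, with no number attached to it.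

Compound 3 `O=S(=O)(NC1=NCCN1C(=S)SN1CCn2c1nsc2=S)c1cccc2ccccc12` is the remaining isomer: naphthalen-1-yl in place of naphthalen-2-yl on a sulfonyl sulfur. Going by the values given here, no measured step bears directly on this change; the only measured step, between compound 1 and compound 2, is unreadable. The expectation for compound 3 in this assay rests solely on compound 2 sitting at the limit of >= 20000 nM in this assay, at which 2 of the 2 values shown sit: the same limit is expected, so the estimated step of a number no higher from compound 2 to compound 3 (the limit leaves the size open) means no movement beyond the scatter. Compound 3 is therefore estimated at 20000 nM, within 8000 nM to 50000 nM, and the result is expected most likely to be reported again only as a limit.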

Compound 3, concentration for 50% growth inhibition: >= 20000 nM
Compound 3: no number, only a limit; the forecaster's own chance of this, stated with the estimate: 80%; the middle value sits exactly at the limit.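

Compound 3 also gives only a limit in this assay, >= 20000 nM. The steps among compound 1, compound 2 and compound 3 therefore cannot be read, as all three values sit at one limit: the limit of >= 20000 nM in this assay, at which 3 of the 3 values shown sit.

The compounds shown leave open how strongly each inhibits growth, and whether the group on the sulfonyl sulfur changes that inhibition.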